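This account rests on a few compounds, and the source may have more. Where it says the series, first, only, none or still open, it means among the compounds named here.

Measured so far:
- compound 1 `COc1ccc2[nH]c(C(=O)N3CC(=O)N(Cc4ccccc4)[C@@H](CCN4CCC5(CC4)CC5)C3)cc2c1`; in a physicochemical assay for solubility, read by spectrophotometry, in phosphate buffer, with a stated time of 2 h, at pH 7.4 (on this read-out lower numbers stand for lower solubility and higher numbers for higher solubility), compound 1 gives > 25000 nM, a limit of the assay.
- compound 2 `COc1ccc2[nH]c(C(=O)N3CC(=O)N(Cc4ccccc4)[C@@H](CN4[C@H](C)COC[C@@H]4C)C3)cc2c1`; in this assay compound 2 gives > 100000 nM, also a limit.
- compound 3 `COc1ccc2[nH]c(C(=O)N3CC(=O)N(Cc4ccccc4)[C@@H](CN4CCC(C(C)C)CC4)C3)cc2c1`; in this assay compound 3 gives 12000 nM.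

Among the compounds with values here, compound 3 thus carries the only number in the set; the two other readings are limits, the limit of > 100000 nM in this assay, at which 1 of the 3 values shown sits, and (the limit of > 25000 nM in this assay, at which 1 of the 3 values shown sits). The steps towards compound 3 are an at least 2.0-fold lower number from compound 1 to compound 3 (0.31 log units; beyond the scatter) and an at least 8.3-fold lower number from compound 2 to compound 3 (0.92 log units; beyond the scatter), both beyond the scatter. The step between compound 1 and compound 2 is a step that the two limits leave unreadable from compound 1 to compound 2.

The next compound is compound 4 `COc1ccc2[nH]c(C(=O)N3CC(=O)N(Cc4ccccc4)[C@@H](CN4CCC5(CCCC5)CC4)C3)cc2c1`. Relative to compound 3 the change is a group of 10 heavy atoms (9 carbon, 1 nitrogen; one five-membered non-aromatic ring of carbon only, one six-membered non-aromatic ring with 1 hetero atom) in place of a group of 9 heavy atoms (8 carbon, 1 nitrogen; one six-membered non-aromatic ring with 1 hetero atom), on a saturated chain carbon bound to a saturated ring carbon. The step from compound 1 to compound 3 bears most on it, since compound 1 also carries a second ring of carbon only fused onto the six-membered ring bearing one hetero atom; that step lowered the number on going to compound 3, so going back to a two-ring amine is expected to raise it. The step is estimated as a 1.7-fold higher number from compound 3 to compound 4 (0.22 log units; within the scatter).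

For compound 4 the expected value in this assay is 20000 nM, with a range of 6000 nM to 60000 nM.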

Compound 4, solubility: 5000 nM
Compound 4: middle estimate off by 4.0-fold (0.60 log units), on the high side; the whole stated range lies above it.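

Within the data shown here, at the place on a saturated chain carbon bound to a saturated ring carbon, this assay now gives the first step in the set that joins two numbers rather than a number and a limit: a 2.4-fold lower number from compound 3 to compound 4 (0.38 log units; beyond the scatter). Swapping 4-isopropylpiperidin-1-yl for the group with one five-membered non-aromatic ring of carbon only thus goes with a lower number, beyond the scatter, and the gain of a ring of carbon only does not raise the reading in this pair. Compounds 1 and 2 stand at limits of the assay, so the steps to compound 4 give only a minimum size, an at least 20-fold lower number from compound 2 to compound 4 (1.30 log units; beyond the scatter) and an at least 5.0-fold lower number from compound 1 to compound 4 (0.69 log units; beyond the scatter), and the two limits are these: the limit of > 100000 nM in this assay, at which 1 of the 4 values shown sits, the limit of > 25000 nM in this assay, at which 1 of the 4 values shown sits.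

One pair cannot show whether the lower number follows the added ring of carbon only or the loss of the isopropyl group, so a cyclohexane or cyclobutane ring in that place would be needed to separate the two. From the compounds shown here alone, how a plain morpholin-4-yl or a piperazin-1-yl group reads at this place also stays open, as does whether a hydroxyl on the five-membered ring shifts the number of compound 4.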